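Swapping chloro for acetyl on a shared indolinone-free core

The source may report more compounds than this note shows. Statements on the series, on what has been measured and on what is new or still open speak of the compounds shown alone.

Three compounds that share one core, differing only in the substituent on the fused benzene-type ring, have been examined for how strongly they slow the growth of a breast cancer cell line. Compound 1, `O=C1Nc2ccc(Cl)cc2/C1=C/c1cccc(OCc2cn(Cc3ccccc3)nn2)c1`, carries a chloro group there. In a functional assay on BT-549 cells (Homo sapiens) for inhibition, read by MTT assay, with a stated time of 48 h (a higher number here means a weaker inhibitor, a lower number a stronger inhibitor), compound 1 is recorded as "not determined" (no result reported); its place among the others is shown only by the values of its two neighbours. Compound 2, `O=C1Nc2cc(Br)ccc2/C1=C\c1cccc(OCc2cn(Cc3ccccc3)nn2)c1`, carries bromo instead; in this assay compound 2 reaches only a limit, > 50000 nM. Compound 3, `O=C1Nc2ccc(F)cc2/C1=C\c1cccc(OCc2cn(Cc3ccccc3)nn2)c1`, carries fluoro; in this assay compound 3 likewise reaches only a limit, > 50000 nM. So far, then, the halogen series gives no number at all, and the limit of > 50000 nM in this assay, at which 2 of the 3 values shown sit, is the whole of what is known.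

Compound 4, `CC(=O)c1ccc2c(c1)/C(=C/c1cccc(OCc3cn(Cc4ccccc4)nn3)c1)C(=O)N2`, changes the substituent itself: acetyl in place of chloro on an aromatic carbon. Among the measured compounds shown here, no measured pair here shows what such a change does, so the size and direction of the step from compound 1 to compound 4 cannot be read from the data; an expectation must rest on the two limits alone. Since compound 2 and compound 3 both sit at the limit, compound 4 is expected to remain weak, with an estimated 40000 nM, in a range from 8000 nM to 120000 nM.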

Compound 4, half-maximal inhibitory concentration: > 50000 nM
Compound 4: no number, only a limit (the forecaster's own chance of this, stated with the estimate: 60%); at least 1.2-fold (0.09 log units) between middle value and limit.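

In this assay compound 4 reaches only a limit, > 50000 nM, not a number. Among the compounds shown here, with no number for compound 1 either, no step from compound 1 to compound 4 can be read. The compounds shown leave open how swapping chloro for acetyl changes potency, and the data so far amount to this: the limit of > 50000 nM in this assay, at which 3 of the 4 values shown sit.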